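The source may hold more compounds than are shown below. What is called first, only, known or untested is meant among the compounds shown, and "the series" means these compounds.

Of the compounds shown here, two have so far been measured in a functional assay on NCI-H460 cells (Homo sapiens) for inhibition, read by sulforhodamine B assay, with a stated time of 48 h; on this read-out lower numbers stand for stronger inhibition of growth and higher numbers for weaker inhibition of growth. Compound 1 `O=C(/C(=C\c1c(-c2ccccc2)[nH]c2ccccc12)S(=O)(=O)c1ccccc1)c1ccccc1` gives 5900 nM in this assay. Compound 2 `COc1ccc2[nH]c(-c3ccccc3)c(/C=C(\C#N)S(=O)(=O)c3ccccc3)c2c1` gives 4600 nM in this assay. Of the two numbers, compound 2 carries the lower one, but its nearest neighbour is compound 1, and the gap between them lies within the scatter of repeated measurements, so the two cannot be told apart on this read-out.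

Compound 3 `N#C/C(=C\c1c(-c2ccccc2)[nH]c2ccccc12)S(=O)(=O)c1ccccc1` has not yet been measured. It differs from compound 2 in a single place: hydrogen in place of methoxy on an aromatic carbon. Going by the values given here, no pair of measured compounds isolates this change, so its effect cannot be read from the data in hand. The expectation is for a step of a 1.1-fold higher number from compound 2 to compound 3 (0.04 log units; within the scatter) in this assay, which amounts to no change beyond the scatter. On that basis compound 3 is estimated at 5000 nM in this assay, with a plausible range from 2000 nM to 13000 nM.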

Compound 3, concentration for 50% growth inhibition: 2700 nM
Estimate against measurement, compound 3: 1.9-fold (0.27 log units) above; the measured number falls inside the stated range.
By their numbers in this assay, from the lowest: compounds 3, 2 and 1 (each within the scatter of the next, the first and the last beyond it).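

Going by these compounds alone, compound 3 gives the first comparisons that change one place at a time. In this assay, hydrogen in place of methoxy on the aromatic carbon gives a 1.7-fold lower number from compound 2 to compound 3 (0.23 log units; within the scatter), so at this position the methoxy group can be lost without a step that stands clear of the scatter. Cyano in place of benzoyl on the double-bonded chain carbon gives a 2.2-fold lower number from compound 1 to compound 3 (0.34 log units; beyond the scatter), a modest step and the only one so far beyond the scatter, which makes this chain carbon the one place shown here where a change can be told apart on this read-out; no supporting data are available to explain either step.

The compounds shown have only hydrogen and methoxy on that aromatic carbon and only cyano and benzoyl on the chain carbon, so it remains open how a hydroxyl, a chlorine or an amine would behave at the first place, or a methyl ester or a primary amide at the second. From the compounds shown here alone, the phenylsulfonyl group and the phenyl group on the shared core stay the same throughout, so the effect of changing either also remains open.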